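Furan-2-yl in place of iodo near the assay limit

The source may hold more compounds than are shown below. What is called first, only, known or untested is meant among the compounds shown, and "the series" means these compounds.

Compound 3 `COc1ncnc2c1c(I)cn2[C@@H]1O[C@H](CO)[C@@H](O)[C@H]1O` was tested in a functional assay on CEM-DNR-bulk cells (Homo sapiens), read by MTT assay, with a stated time of 72 h (a lower number here means a stronger inhibitor, a higher number a weaker inhibitor), and in this assay compound 3 gives only > 20000 nM, which is a limit of the assay and not a number. Compound 1 `Cc1ncnc2c1c(I)cn2[C@@H]1O[C@H](CO)[C@@H](O)[C@H]1O` carries methyl where compound 3 carries methoxy, and in this assay compound 1 gives 12600 nM. That exchange gives an at least 1.5-fold higher number from compound 1 to compound 3 (0.20 log units; that floor lies within the scatter). Compound 2 `COc1ncnc2c1c(-c1ccccc1)cn2[C@@H]1O[C@H](CO)[C@@H](O)[C@H]1O` carries phenyl where compound 3 carries iodo, and in this assay compound 2 also stops at > 20000 nM, again a limit. Because both sit at the limit of > 20000 nM in this assay, at which 2 of the 3 values shown sit, the step that the two limits leave unreadable from compound 2 to compound 3 is unreadable.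

Compound 4 `COc1ncnc2c1c(-c1ccco1)cn2[C@@H]1O[C@H](CO)[C@@H](O)[C@H]1O` differs from compound 3 in one place: furan-2-yl in place of iodo on an aromatic carbon. For the measured compounds named here, the closest measured comparison is the exchange of iodo for phenyl, and that step could not be read, while the only other aromatic group at this position left compound 2 at the limit. Compound 4 is therefore expected to give about 25000 nM, within 10000 nM to 60000 nM. The expected step that the limit leaves unreadable from compound 3 to compound 4 means no change beyond the scatter, with a high chance that only a limit is reported again.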

Compound 4, half-maximal inhibitory concentration: 160 nM
Beside the measured number, compound 4's estimate is 160-fold (2.19 log units) above it; measured number below the stated range.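

This aromatic carbon of the five-membered ring is not closed to a larger aromatic group: in this assay, exchanging iodo for furan-2-yl gives an at least 120-fold lower number from compound 3 to compound 4 (2.09 log units; beyond the scatter). The kind of aromatic ring placed there also matters, as exchanging phenyl for furan-2-yl gives an at least 120-fold lower number from compound 2 to compound 4 (2.09 log units; beyond the scatter), so an aromatic ring here does not by itself give a low number. Both steps start from a limit and not from a number, and the step between the two compounds at that limit cannot be read: the limit of > 20000 nM in this assay, at which 2 of the 4 values shown sit.

The compounds shown leave open whether the low number is particular to furan-2-yl or extends to other five-membered aromatic rings, such as thiophen-2-yl or pyrrol-2-yl. They also leave open how compound 4 would respond if its methoxy group were exchanged for methyl or an amine while furan-2-yl stayed in place.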